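Fluorophenyl series: trifluoromethyl replacing fluoro at the anilino ring

The source may hold more compounds than are shown below. What is called first, only, known or untested is meant among the compounds shown, and "the series" means these compounds.

Measured compounds:
compound 1 `C=CC(=O)Nc1cccc(NC(=O)CSc2nc(Nc3ccccc3F)c3ccccc3n2)c1`: 6580 nM
compound 2 `C=CC(=O)Nc1cccc(NC(=O)CSc2nc(Nc3cccc(F)c3)c3ccccc3n2)c1`: 2030 nM
compound 3 `C=CC(=O)Nc1cccc(NC(=O)CSc2nc(Nc3ccc(F)cc3)c3ccccc3n2)c1`: 4430 nM

In a functional assay on NCI-H1975 cells (Homo sapiens) for inhibition, read by MTT assay, with a stated time of 72 h (on this read-out higher numbers stand for weaker inhibition and lower numbers for stronger inhibition), compound 3 gives 4430 nM, the second highest of the three numbers; the two steps that end at it read a 1.5-fold lower number from compound 1 to compound 3 (0.17 log units; within the scatter) and a 2.2-fold higher number from compound 2 to compound 3 (0.34 log units; beyond the scatter). Compound 4 `C=CC(=O)Nc1cccc(NC(=O)CSc2nc(Nc3ccc(C(F)(F)F)cc3)c3ccccc3n2)c1` is not yet measured; it differs from compound 3 by trifluoromethyl in place of fluoro on an aromatic carbon. The measured steps, a 3.2-fold lower number from compound 1 to compound 2 (0.51 log units; beyond the scatter) and a 2.2-fold higher number from compound 2 to compound 3 (0.34 log units; beyond the scatter), concern only where fluoro sits on that ring, not its replacement, so none of them bears directly on this change. With no step of this kind in hand, the expectation for compound 4 is a number near that of compound 3, a 1.1-fold lower number from compound 3 to compound 4 (0.04 log units; within the scatter), with a wide margin. The estimate for compound 4 is 4000 nM, expected between 1300 nM and 12000 nM.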

Compound 4, half-maximal inhibitory concentration: 12900 nM
Estimate against measurement, compound 4: 3.2-fold (0.51 log units) below; the measured number lies above the stated range.
By their numbers in this assay, from the lowest: compound 2; then compounds 3, 1 and 4 (each within the scatter of the next, the first and the last beyond it).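

In this assay, within the data shown here, the first direct reading of trifluoromethyl in place of fluoro on this aromatic carbon is a 2.9-fold higher number from compound 3 to compound 4 (0.46 log units; beyond the scatter), so this replacement weakens inhibition beyond the scatter. The gap to the best fluoro isomer widens to a 6.4-fold higher number from compound 2 to compound 4 (0.80 log units; beyond the scatter), whereas a 2.0-fold higher number from compound 1 to compound 4 (0.29 log units; within the scatter) leaves compound 4 not separated from compound 1. Nothing available accounts for the rise.

Still open, as far as these compounds go, is how chloro, methoxy or an amine would read on the same carbon. Also open, from the compounds shown here alone, is whether trifluoromethyl would give a similar step where compound 2 carries its fluoro.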